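The compounds below may be only part of what the source reports. "The series", "measured", "known", "first", "only" and "open" are said of these compounds alone.

Three compounds have been measured in a functional assay on the whole organism with Rattus norvegicus as the target, at a dose of 40 mg/kg by the intraperitoneal route; on this read-out higher numbers stand for more inhibition at the one dose given (going by the name of the read-out) and lower numbers for less inhibition:

compound 1 `COC(=O)Nc1c(C)nc2c(OCc3ccccc3)cccn12`: 0%
compound 2 `Cc1nc2c(OCc3ccccc3)cccn2c1/N=C/N(C)C`: 64%
compound 3 `CCNc1c(C)nc2c(OCc3ccccc3)cccn12`: 95%

Compound 3 stands highest of the three. Its nearest neighbour is compound 2, with a number 31 percentage points higher from compound 2 to compound 3 (beyond the scatter), and the widest gap is a number 95 percentage points higher from compound 1 to compound 3 (beyond the scatter). Compound 4 `CCCN(CCC)c1c(C)nc2c(OCc3ccccc3)cccn12` has not yet been measured. It differs from compound 3 in one place: dipropylamino in place of ethylamino on an aromatic carbon. Among the measured compounds shown here, both measured steps that reach compound 3 bring the ethylamino group in, and both rise strongly; no step shows what happens when that group is changed again, so the bearing is indirect. Since the group that carried the highest number now leaves, a step downward is expected, a number 35 percentage points lower from compound 3 to compound 4 (beyond the scatter), with wide uncertainty. Compound 4 is therefore expected to give about 60%, between 20% and 95%.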

Compound 4, a percentage reported as inhibition, in the whole organism at one dose (the size of the read-out at that dose, not a potency): 60%
Compound 4: the middle estimate sits on the measured number at the digits printed; measured number inside the range.
By their numbers in this assay, from the lowest: compound 1; then compounds 4 and 2 (each within the scatter of the next); then compound 3.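

Compound 4 shows that this aromatic carbon accepts dipropylamino, which has no hydrogen-bond donor, yet ethylamino is still preferred in this assay, with a number 35 percentage points lower from compound 3 to compound 4 (beyond the scatter). The bulkier amine keeps a clear advantage over the (methoxycarbonyl)amino group, with a number 60 percentage points higher from compound 1 to compound 4 (beyond the scatter). Against the group in compound 2, it gives a number 4 percentage points lower from compound 2 to compound 4 (within the scatter).

Propylamino, which keeps the amine hydrogen, and dimethylamino, which has two short chains, remain open, so the loss cannot yet be divided between chain length and the missing hydrogen. Nothing shown here explains these steps.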